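Chloromethyl extension checked across two matched pairs

A few compounds are considered here, and "the series" means these few. Any claim that something is new, unique, unknown or untested is made for them only; others in the source may bear on it.

Measured compounds:
compound 1 `CC(=O)N1N=C(c2ccc(N3CCN(C)CC3)cc2)CC1c1ccc(N(C)C)cc1`: -1.9%
compound 2 `CN1CCN(c2ccc(C3=NN(C(=O)CCCl)C(c4ccc(N(C)C)cc4)C3)cc2)CC1`: -0.2%
compound 3 `CC(=O)N1N=C(c2ccc(-n3ccnc3)cc2)CC1c1ccc(N(C)C)cc1`: -2.1%

All three values come from a functional assay on NCI-H1975 cells (Homo sapiens) for inhibition, read by sulforhodamine B assay, tested at 10 uM; a higher number here means more inhibition at the concentration tested (going by the name of the read-out), a lower number less inhibition. Compound 2 differs from compound 1 by chloromethyl in place of hydrogen on a saturated chain carbon bound to a carbonyl carbon; the step of a number 1.7 percentage points higher from compound 1 to compound 2 (within the scatter) is within the scatter. The cores of compound 1 and compound 3 differ by 1H-imidazol-1-yl in place of 4-methylpiperazin-1-yl on an aromatic carbon, and the step of a number 0.2 percentage points lower from compound 1 to compound 3 (within the scatter) is also within the scatter. Compound 4 `CN(C)c1ccc(C2CC(c3ccc(-n4ccnc4)cc3)=NN2C(=O)CCCl)cc1` differs from compound 3 by chloromethyl in place of hydrogen on a saturated chain carbon bound to a carbonyl carbon, the same change already seen from compound 1 to compound 2, at the same place. Since this change gave no step beyond the scatter on the core of compound 1, the step from compound 3 to compound 4 is expected to be a number 1.6 percentage points higher from compound 3 to compound 4 (within the scatter), resting on a number 1.7 percentage points higher from compound 1 to compound 2 (within the scatter). Compound 4 is therefore estimated at -0.5%, between -12% and 11%.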

Compound 4, a percentage reported as inhibition, at one concentration (the size of the read-out at that concentration, not a potency): -2.5%
Estimate against measurement, compound 4: 2 percentage points above; the range from low to high includes it.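

In this assay, chloromethyl in place of hydrogen gives a number 0.4 percentage points lower from compound 3 to compound 4 (within the scatter), and 1H-imidazol-1-yl in place of 4-methylpiperazin-1-yl gives a number 2.3 percentage points lower from compound 2 to compound 4 (within the scatter). The chloromethyl change reads alike on both cores: the same change on two cores in this assay, a number 1.7 percentage points higher (within the scatter) from compound 1 to compound 2 and a number 0.4 percentage points lower (within the scatter) from compound 3 to compound 4, 2.1 percentage points apart, within the scatter of two such steps. Among the compounds shown here, the 1H-imidazol-1-yl change also reads alike, but with every step inside the scatter this shows only that neither change has a readable effect at this concentration, not that a real effect of either change would carry from one core to another: the same change on two cores in this assay, a number 0.2 percentage points lower (within the scatter) from compound 1 to compound 3 and a number 2.3 percentage points lower (within the scatter) from compound 2 to compound 4, 2.1 percentage points apart, within the scatter of two such steps.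

The compounds shown hold only acetyl and (2-chloroethyl)carbonyl at the carbonyl end and only 4-methylpiperazin-1-yl and 1H-imidazol-1-yl on the aromatic carbon. Going by these compounds, whether an amine or a longer chain at the first place, or a carboxylic acid at the second, would move the number remains open.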